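The source may hold more compounds than are shown below. What is called first, only, known or untested is meant among the compounds shown, and "the series" means these compounds.

Compound 3 `C=CCOc1c(C)c(C)c2c(c1C)CCC(C)(COc1ccc(/C=C3\SC(=O)NC3=O)cc1OCC)O2` gives 75% in a functional assay on MCF7 cells (Homo sapiens), tested at 7.5 uM; on this read-out higher numbers stand for a weaker effect at the one concentration tested and lower numbers for a stronger effect. Among the three compounds measured, compound 3 stands second highest of the three numbers. Its nearest neighbour is compound 2 `CC(C)=CCOc1c(C)c(C)c2c(c1C)CCC(C)(COc1ccc(/C=C3\SC(=O)NC3=O)cc1-c1ccc(F)cc1)O2`, which gives 85%, a number within the usual scatter of compound 3's. The furthest is compound 1 `CC(C)=CCOc1c(C)c(C)c2c(c1C)CCC(C)(COc1ccc(/C=C3\SC(=O)NC3=O)cc1C)O2`, which gives 27%, a lower number that lies beyond the scatter. Compound 4 `CCOc1cc(/C=C2\SC(=O)NC2=O)ccc1OCC1(C)CCc2c(C)c(OCC=C(C)C)c(C)c(C)c2O1` has not yet been measured. It differs from compound 3 in one place: 2-methylprop-1-en-1-yl in place of vinyl on a saturated chain carbon bound to an oxygen on an aromatic ring; cut one bond further out, the same difference reads allyl to 3-methylbut-2-en-1-yl. Within the data shown here, the only measured step, a number 58 percentage points higher from compound 1 to compound 2 (beyond the scatter), concerns a different change, 4-fluorophenyl in place of methyl on an aromatic carbon, and so does not bear on the change at hand. Among the measured compounds shown here, no measured pair separates allyl from 3-methylbut-2-en-1-yl on its own. The account therefore expects no step beyond the scatter, a number 3 percentage points lower from compound 3 to compound 4 (within the scatter). Compound 4 is estimated at 72%, within a range from 52% to 92%.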

Compound 4, a percentage reported as activity, at one concentration (the size of the read-out at that concentration, not a potency): 54%
For compound 4 the middle estimate is 18 percentage points above the measured one; the measured number falls inside the stated range.
By their numbers in this assay, from the lowest: compound 1; then compound 4; then compounds 3 and 2 (each within the scatter of the next).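

In this assay, the group on the saturated chain carbon bound to an oxygen on an aromatic ring proves to matter: going from allyl to 3-methylbut-2-en-1-yl gives a number 21 percentage points lower from compound 3 to compound 4 (beyond the scatter) on the ethoxy-bearing compounds. With 3-methylbut-2-en-1-yl held fixed, ethoxy on the aromatic carbon gives a number 31 percentage points lower from compound 2 to compound 4 (beyond the scatter) when it replaces 4-fluorophenyl and a number 27 percentage points higher from compound 1 to compound 4 (beyond the scatter) when it replaces methyl, so ethoxy separates from both of those groups. Nothing measured here accounts for these differences.

The compounds shown leave open whether the allyl to 3-methylbut-2-en-1-yl step has the same size when methyl or 4-fluorophenyl replaces ethoxy. They also leave open how a saturated chain such as 3-methylbutyl or a longer chain such as geranyl would read at this place.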